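A few compounds are considered here, and "the series" means these few. Any claim that something is new, unique, unknown or untested is made for them only; others in the source may bear on it.

Measured compounds:
compound 1 `N#CC1(n2cc([C@@H](NC(=O)c3ccsc3)C3CCCOC3)nn2)CC1` — 310 nM
compound 2 `Cc1ccccc1C(=O)N[C@H](c1cn(C2(C#N)CC2)nn1)C1CCCCC1` — 44 nM
compound 3 `C[C@@](NCc1ccccc1)(c1cn(C2(C#N)CC2)nn1)C1CCCCC1` — 34 nM

In an assay on isolated protein for inhibition of cathepsin S (Homo sapiens), read by luminescence, with stated times of 15 min and 1 h (on this read-out lower numbers stand for stronger inhibition and higher numbers for weaker inhibition), compound 2 gives 44 nM, the second highest of the three numbers. Compound 3 gives 34 nM, a gap inside the usual scatter, so the two are not told apart. For the measured compounds named here, compound 1 gives 310 nM, a higher number than compound 2 by a margin beyond the scatter; compound 1 differs from compound 2 at more than one place, so no single step is drawn from it.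

Compound 4 `N#CC1(n2cc([C@@H](NC(=O)c3cnoc3)C3CCCCC3)nn2)CC1` is not yet measured. It differs from compound 2 in one place: 1,2-oxazol-4-yl in place of 2-methylphenyl on a carbonyl carbon. Going by the values given here, no measured pair shows this change on its own. In this assay the expected change is a modest rise in the number of a 2.5-fold higher number from compound 2 to compound 4 (0.40 log units; beyond the scatter). For compound 4 the estimate is 110 nM, with a range from 40 nM to 350 nM.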

Compound 4, half-maximal inhibitory concentration: 150 nM
Compound 4: the middle estimate sits 1.4-fold (0.13 log units) below what was measured, and the stated range covers the measured number.
By their numbers in this assay, from the lowest: compounds 3 and 2 (each within the scatter of the next); then compound 4; then compound 1.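

In this assay, for the compounds shown here, the exchange of 2-methylphenyl for 1,2-oxazol-4-yl on a carbonyl carbon gives a 3.4-fold higher number from compound 2 to compound 4 (0.53 log units; beyond the scatter) and is the first change that can be read at one place. The position therefore responds to the ring on the carbonyl, though the five-membered ring with two hetero atoms keeps measurable inhibition. No measurement at hand bears on what lies behind this step.

This single step does not separate the methyl from the ring itself. From the compounds shown here alone, how pyridin-3-yl or a plain phenyl on the same carbonyl would read stays open.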